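Bile acid receptor agonists: swapping phenyl for benzofuranyl

The source may report more compounds than this note shows. Statements on the series, on what has been measured and on what is new or still open speak of the compounds shown alone.

Of the compounds shown here, three sharing one core have been measured in an assay on isolated protein for agonist activity at Bile acid receptor (Homo sapiens), read by AlphaScreen, with a stated time of 30 min; a lower number here means a smaller maximal response, a higher number a larger maximal response. Compound 1 `Cc1ccccc1-n1nc(C)c2c1NC(=O)[C@H](C)S[C@@H]2c1ccc(-c2ccccc2)cc1` gives 24%, the lowest of the three numbers. Compound 2 `CCc1ccccc1-n1nc(C)c2c1NC(=O)[C@H](C)S[C@@H]2c1ccc(Oc2ccccc2)cc1` gives 190%, and compound 3 `COc1ccccc1-n1nc(C)c2c1NC(=O)[C@H](C)S[C@@H]2c1ccc(Oc2ccccc2)cc1` gives 37%. The gap from compound 1 to compound 3 is beyond the scatter, and the gap to compound 2 is far larger. Among the measured compounds shown here, the one measured step that changes a single place is a number 153 percentage points lower from compound 2 to compound 3 (beyond the scatter); it concerns the ring carrying the ethyl or methoxy group, not the outer ring at the other end.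

Compound 4 `Cc1ccccc1-n1nc(C)c2c1NC(=O)[C@H](C)S[C@@H]2c1ccc(-c2cc3ccccc3o2)cc1` differs from compound 1 by 1-benzofuran-2-yl in place of phenyl on an aromatic carbon. For the measured compounds named here, no measured step touches this position, because compound 1 and compound 2 differ in two places at once, so the measured data offer no direct guide. Given the low starting point of compound 1 at 24%, a modest rise is expected, estimated as a number 21 percentage points higher from compound 1 to compound 4 (beyond the scatter). For compound 4 the expected value in this assay is 45%, ranging from 15% to 120%.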

Compound 4, largest response reached (reported as efficacy), in percent of the reference or control that the assay uses: 17%
For compound 4 the middle estimate is 28 percentage points above the measured one, and the stated range covers the measured number.
By their numbers in this assay, from the lowest: compounds 4 and 1 (each within the scatter of the next); then compound 3; then compound 2.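

Putting 1-benzofuran-2-yl in place of phenyl on this aromatic carbon gives a number 7 percentage points lower from compound 1 to compound 4 (within the scatter) in this assay. Among the compounds shown here, this is the first measured step at this position, and it shows that the larger group with two fused rings and one hydrogen-bond acceptor leaves the maximal response indistinguishable from that of phenyl, with both compounds in the low range. No supporting measurement is available to explain this result.

On these data alone, what a carboxylic acid or an amine on this same aromatic carbon would do to the response remains open. As far as these compounds go, it is also open whether the same swap would read the same way on a compound carrying ethyl, rather than the methyl of compound 1, on the other aromatic ring.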